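The compounds below may be only part of what the source reports. "The series", "measured", "known", "first", "only" and "open" are said of these compounds alone.

Compound 1 `CO[C@@H]1[C@@H](OC)[C@H](Cc2ccccc2)O[C@@H]2CO[C@@H](c3ccccc3)O[C@@H]12` gives 20 ug/mL in a functional assay on HEL cells (Homo sapiens) for cytotoxicity; a higher number here means that more compound is tolerated, a lower number that less compound is tolerated.
Compound 2 `O[C@@H]1[C@@H](O)[C@H](c2ccccc2)O[C@@H]2CO[C@@H](c3ccc(C(F)(F)F)cc3)O[C@@H]12` gives 400 ug/mL in this assay.
Compound 3 `CO[C@@H]1[C@@H](OC)[C@H](c2ccccc2)O[C@@H]2CO[C@@H](c3ccco3)O[C@@H]12` gives "not determined" (no result reported) in this assay.

In this assay, compound 1 gives 20 ug/mL and compound 2 gives 400 ug/mL. Compound 3 has no number in this assay, so its place among these values is simply unknown. Compound 4 `CO[C@@H]1[C@@H](OC)[C@H](c2ccccc2)O[C@@H]2CO[C@@H](C3CCCCC3)O[C@@H]12` has not yet been measured. It differs from compound 3 in one place: cyclohexyl in place of furan-2-yl on a saturated ring carbon. Among the compounds with values here, no measured pair of compounds shows the effect of such a change, and compound 3 itself offers no starting value, so neither the direction nor the size of the step can be read from the data. The two measured compounds only mark out a wide span. For compound 4 in this assay a value of 100 ug/mL is expected, with a likely range from 20 ug/mL to 400 ug/mL.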

Compound 4, minimum cytotoxic concentration: 20 ug/mL
Compound 4: middle estimate off by 5.0-fold (0.70 log units), on the high side; the measured number falls inside the stated range.
By their numbers in this assay, from the lowest: compounds 1 and 4 (each within the scatter of the next); then compound 2.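

Within the data shown here, compound 3 has no number in this assay, so no step to compound 4 can be read, and no measured evidence bears on this result. As far as these compounds go, how replacing furan-2-yl with cyclohexyl changes the tolerated concentration stays open.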